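Notes on the anilide cap: compound 2 toward compound 4

The source may hold more compounds than are shown below. What is called first, only, known or untested is meant among the compounds shown, and "the series" means these compounds.

For the measured compounds named here, the three compounds measured so far share one core and differ only in the group on the carbonyl carbon of the anilide. Compound 1 `CC(=O)Nc1cccc(NC(=O)COc2ccc3c(=O)ccoc3c2)c1` gives 136 nM in an assay on isolated protein for inhibition of Rho-associated protein kinase 2 (Homo sapiens), read by scintillation counting, radiometric assay and 33P incorporation, with a stated time of 40 min, in the presence of a further agent that is not named here; a higher number here means a weaker inhibitor, a lower number a stronger inhibitor. Compound 2 `CCCC(=O)Nc1cccc(NC(=O)COc2ccc3c(=O)ccoc3c2)c1` gives 176 nM in this assay, the highest of the three numbers; the step of a 1.3-fold higher number from compound 1 to compound 2 (0.11 log units; within the scatter) lies within the scatter, so compound 1 and compound 2 cannot be ranked against each other. Compound 3 `Cc1nc(C(=O)Nc2cccc(NC(=O)COc3ccc4c(=O)ccoc4c3)c2)cs1` gives 33 nM, and both a 4.1-fold lower number from compound 1 to compound 3 (0.62 log units; beyond the scatter) and a 5.3-fold lower number from compound 2 to compound 3 (0.73 log units; beyond the scatter) lie beyond the scatter.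

Compound 4 `Cc1cc(C(=O)Nc2cccc(NC(=O)COc3ccc4c(=O)ccoc4c3)c2)no1` is not yet measured. It differs from compound 2 by 5-methyl-1,2-oxazol-3-yl in place of propyl on a carbonyl carbon. The step that bears most directly on this change is a 5.3-fold lower number from compound 2 to compound 3 (0.73 log units; beyond the scatter), where another five-membered aromatic ring with 2 hetero atoms took the place of a chain on the same carbonyl carbon; a 4.1-fold lower number from compound 1 to compound 3 (0.62 log units; beyond the scatter) points the same way. Going by the values given here, on that basis a step in this assay toward a lower number, of modest size and beyond the scatter, is expected for compound 4, though with only one such precedent the size is uncertain. Compound 4 is expected to give about 45 nM. Compound 4 is estimated to fall between 18 nM and 110 nM. That estimate corresponds to an expected step of a 3.9-fold lower number from compound 2 to compound 4 (0.59 log units; beyond the scatter).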

Compound 4, half-maximal inhibitory concentration: 5 nM
Compound 4: middle estimate off by 9.0-fold (0.95 log units), on the high side; the whole stated range lies above it.
By their numbers in this assay, from the lowest: compound 4; then compound 3; then compounds 1 and 2 (each within the scatter of the next).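

For the compounds shown here, the position on the carbonyl carbon has a far wider range than the earlier compounds showed: a 35-fold lower number from compound 2 to compound 4 (1.55 log units; beyond the scatter) and a 27-fold lower number from compound 1 to compound 4 (1.43 log units; beyond the scatter) are both large steps, and compound 4 is the strongest inhibitor of the four in this assay. Going by these compounds alone, the earlier compounds showed only that a ring could outdo a chain here, whereas a 6.6-fold lower number from compound 3 to compound 4 (0.82 log units; beyond the scatter) shows that the two methyl-bearing five-membered aromatic rings are not interchangeable, so the ring's identity matters at this position as well as its presence. No measurement at hand accounts for the difference between 5-methyl-1,2-oxazol-3-yl and 2-methyl-1,3-thiazol-4-yl on this carbonyl carbon.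

The compounds shown cannot separate the contribution of the methyl from that of the ring itself, so the reading of an unsubstituted 1,2-oxazol-3-yl or a 4-methyl-1,2-oxazol-3-yl on the same carbonyl carbon stays open. Also open, as far as these compounds go, is whether a phenyl or a pyridinyl there would keep the gain, or whether it is confined to five-membered rings with 2 hetero atoms.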